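Dropping one chloro from a dichlorophenyl anilide

The source may report more compounds than this note shows. Statements on the series, on what has been measured and on what is new or still open speak of the compounds shown alone.

Of the compounds shown here, three sharing one core have been tested in a functional assay on cells (Panel NCI-60 (60 carcinoma cell lines), Homo sapiens) for inhibition, read by sulforhodamine B assay, with a stated time of 48 h; on this read-out lower numbers stand for higher toxicity in this test and higher numbers for lower toxicity in this test. Compound 1 `CN1CCN(CCCOc2cccc3nc(Nc4ccc(Cl)c(C(F)(F)F)c4)ccc23)CC1` gives 8130 nM. Compound 2 `CN1CCN(CCCOc2cccc3nc(Nc4ccc(F)c(F)c4)ccc23)CC1` gives 16200 nM, and compound 3 `CN1CCN(CCCOc2cccc3nc(Nc4cc(Cl)cc(Cl)c4)ccc23)CC1` gives 8320 nM. Compound 3 thus sits close to compound 1, the gap between them being a 1.0-fold higher number from compound 1 to compound 3 (0.01 log units; within the scatter), and somewhat apart from compound 2, with a 1.9-fold lower number from compound 2 to compound 3 (0.29 log units; within the scatter); every step among the three, including a 2.0-fold higher number from compound 1 to compound 2 (0.30 log units; within the scatter), stays inside the scatter, so the three numbers cannot be ranked.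

Compound 4 `CN1CCN(CCCOc2cccc3nc(Nc4cccc(Cl)c4)ccc23)CC1` differs from compound 3 by one change: hydrogen in place of chloro on an aromatic carbon. Among the measured compounds shown here, no measured pair removes a single group from the anilide ring in this way; the pairs at hand swap one whole ring for another. Those swaps, a chlorotrifluoromethyl ring against a difluoro ring or against a dichloro ring, all left the read-out within the scatter, which suggests that this part of the molecule tolerates changes without large shifts. Removing one chloro is a smaller change than any of those swaps, so the expected step of a 1.3-fold higher number from compound 3 to compound 4 (0.12 log units; within the scatter) is none beyond the scatter, with a slight lean toward a higher number. Compound 4 is therefore estimated at 11000 nM, within a range from 5000 nM to 25000 nM.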

Compound 4, concentration lethal to 50% of the cells: 10700 nM
The estimate for compound 4 lay 1.0-fold (0.01 log units) above the measured number; low and high end bracket the measured number.
By their numbers in this assay, from the lowest: compounds 1, 3, 4 and 2 (each within the scatter of the next).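

Among the compounds shown here, removing one chloro from the 3,5-dichlorophenyl ring is the first single-group removal on this ring, and in this assay it gives a 1.3-fold higher number from compound 3 to compound 4 (0.11 log units; within the scatter) with a single chloro left in place. The 3-chlorophenyl ring also cannot be told apart from the other two rings, with a 1.5-fold lower number from compound 2 to compound 4 (0.18 log units; within the scatter) and a 1.3-fold higher number from compound 1 to compound 4 (0.12 log units; within the scatter) as the steps from those rings. So one chloro at this position can go without the read-out leaving the scatter, the four compounds cannot be ranked, and nothing measured here speaks to what lies behind such small steps.

Going by these compounds, what stays open is whether the second chloro can also go, leaving a plain phenyl ring, and whether a group of another kind at this position, such as an amine, a hydroxyl or a carboxylic acid, would move the read-out beyond the scatter. All four compounds also carry the same side chain on the shared core, so these numbers say nothing about how a shorter or longer chain there would read.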